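The source may hold more compounds than are shown below. What is called first, only, known or untested is meant among the compounds shown, and "the series" means these compounds.

Compound 1, whose structure is `CC(C)=CCC[C@H](C)c1ccc(C)cc1O`, is the starting point. In a functional assay on MDA-MB-231 cells (Homo sapiens) for inhibition, read by MTT assay, with a stated time of 72 h (a higher number here means a weaker inhibitor, a lower number a stronger inhibitor), compound 1 gives > 50000 nM, and this is a limit of the assay rather than a number. The evidence for compound 1 amounts to the limit of > 50000 nM in this assay, at which 1 of the 2 values shown sits, so compound 1 stands only at the edge of what the assay can report, with no measured value of its own.

A second measured compound, compound 2 with structure `CC(C)=CCC[C@H](C)c1ccc(C)c2c1OCN(CCCCCO)C2`, gives 5400 nM in this assay.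

The step to be followed leads from compound 1 to compound 3, whose structure is `CC(C)=CCC[C@H](C)c1ccc(C)c(CNCCCCCO)c1O`. The change is ((5-hydroxypentyl)amino)methyl in place of hydrogen on an aromatic carbon. For the measured compounds named here, no step between two measured compounds is available for comparison, so the size of this step can only be expected. Because compound 2 gives 5400 nM, compound 3 is expected to be a measurable inhibitor, and the step of an at least 10-fold lower number from compound 1 to compound 3 (1.00 log units; beyond the scatter) is expected to run toward stronger inhibition, beyond the scatter. For compound 3 the estimate in this assay is 5000 nM, within a range from 1500 nM to 20000 nM.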

Compound 3, half-maximal inhibitory concentration: 10700 nM
For compound 3 the middle estimate is 2.1-fold (0.33 log units) below the measured one; the measured number falls inside the stated range.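

Placing ((5-hydroxypentyl)amino)methyl in place of hydrogen on this aromatic carbon, ortho to a hydroxy group and ortho to a methyl group, gives the core of compound 1 a readable effect in this assay, where compound 3 reaches 10700 nM. The change, which adds a chain with no ring, produces an at least 4.6-fold lower number from compound 1 to compound 3 (0.66 log units; beyond the scatter), so this single substitution on an open position is enough to move the result toward stronger inhibition, by more than the scatter of the measurement. The true size of the step remains unknown and could be larger than printed, because the starting point is a limit of the assay and not a number: the limit of > 50000 nM in this assay, at which 1 of the 3 values shown sits.

The compounds shown leave open which part of the new group carries the gain, since a simple aminomethyl group, a longer chain, or a carboxylic acid at the end of the chain in place of the hydroxy group would each separate the amine from the chain and its end. They also leave open whether the same group would have a similar effect on another aromatic carbon of the shared core.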